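The source may hold more compounds than are shown below. What is called first, only, known or untested is meant among the compounds shown, and "the series" means these compounds.

In a functional assay (Cavia porcellus) with sulfonylurea receptors; K-ATP channels (Homo sapiens) as the target (a lower number here means a stronger inhibitor, a higher number a weaker inhibitor), compound 1 `CC(O)(C(=O)Nc1cccc(S(=O)(=O)c2ccccc2)c1)C(F)(F)F` is recorded only as a limit, > 30000 nM, and not as a number (the limit of > 30000 nM in this assay, at which 1 of the 3 values shown sits). Compound 2 `CC(O)(C(=O)Nc1ccc(C#N)c(S(=O)(=O)c2ccccc2)c1)C(F)(F)F` gives 2600 nM in this assay. For the measured compounds named here, the only measured step between neighbouring structures is an at least 11-fold lower number from compound 1 to compound 2 (1.06 log units; beyond the scatter). Compound 3 `COc1ccccc1S(=O)(=O)c1ccc(NC(=O)C(C)(O)C(F)(F)F)cc1` gives 1600 nM in this assay; this number and that of compound 2 lie within the scatter of each other, so the two cannot be told apart. Compound 1 stands aside, recorded only as a limit.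

Compound 4 `CC(O)(C(=O)Nc1ccc(S(=O)(=O)c2ccc([N+](=O)[O-])cc2)cc1)C(F)(F)F` differs from compound 3 by 4-nitrophenyl in place of 2-methoxyphenyl on a sulfonyl sulfur. Going by the values given here, the one measured step concerns a cyano group entering on the ring that carries the amide, while this change is on the other ring, attached to the sulfonyl sulfur; no measured pair shows what a change there does. The step from compound 1 to compound 2 therefore does not bear on it, and no direction can be drawn from the shown data. Compound 4 is expected to give 1800 nM in this assay, with a range from 500 nM to 6500 nM. This expected step of a 1.1-fold higher number from compound 3 to compound 4 (0.05 log units; within the scatter) is estimated to stay within the scatter.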

Compound 4, half-maximal inhibitory concentration: > 30000 nM
Compound 4 ended at the assay's limit; the forecaster's own chance of this, stated with the estimate: 10%; middle value at least 16-fold (1.22 log units) from the limit.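

In this assay compound 4 is recorded only as a limit and not as a number, a second compound at that ceiling: the limit of > 30000 nM in this assay, at which 2 of the 4 values shown sit.

Putting 4-nitrophenyl in place of 2-methoxyphenyl on a sulfonyl sulfur gives an at least 18-fold higher number from compound 3 to compound 4 (1.27 log units; beyond the scatter), so the group on this sulfur can by itself separate a measurable inhibitor from one that reaches the limit. For the compounds shown here, the earlier compounds could not show this, as their only measured step was a cyano group entering on the ring that carries the amide, which left the ring on the sulfonyl sulfur untested.

This single swap removes a methoxy group and brings in a nitro group, and it also changes where the substituent sits on the ring, so the compounds shown cannot say which of these differences matters. As far as these compounds go, how other groups on that ring would read in this assay, for example an amine, a carboxylic acid or a longer alkyl chain, also stays open, as does whether the change would act the same way on the core of compound 2, which carries the cyano group.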